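This account rests on a few compounds, and the source may have more. Where it says the series, first, only, none or still open, it means among the compounds named here.

Compound 1 `CNC(=O)/C=C/c1ccncc1-c1ccc2[nH]ccc2c1` and compound 2 `O=C(/C=C/c1ccncc1-c1ccc2[nH]ccc2c1)N1CCOCC1` share one core and differ only in the group on the carbonyl carbon. In an assay on a protein complex for inhibition of CDK8/Cyclin C (Homo sapiens), with a stated time of 1 h (a higher number here means a weaker inhibitor, a lower number a stronger inhibitor), compound 1 gives 51.9 nM, while compound 2 gives 190 nM, so that the step of a 3.7-fold higher number from compound 1 to compound 2 (0.56 log units; beyond the scatter) is modest but beyond the scatter, and compound 2 stands as the higher of the two numbers measured. Compound 3 `O=C(O)/C=C/c1ccncc1-c1ccc2[nH]ccc2c1` keeps the same core and shows (hydroxy in place of morpholin-4-yl on a carbonyl carbon). Going by the values given here, the only measured step at this carbonyl carbon is the one from the methylamino compound to the morpholine compound, and no measured compound carries a hydroxy there, so no step covers this exact change. Compound 3 is therefore expected to differ from compound 2 in this assay by a 2.1-fold higher number from compound 2 to compound 3 (0.32 log units; beyond the scatter), a shift of modest size. Compound 3 is estimated at 400 nM, with a range from 100 nM to 1500 nM.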

Compound 3, half-maximal inhibitory concentration: 17 nM
Estimate against measurement, compound 3: 24-fold (1.37 log units) above; measured number below the stated range.
By their numbers in this assay, from the lowest: compound 3; then compound 1; then compound 2.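

At this carbonyl carbon, the change reaches further than the earlier pair showed: in this assay the step from morpholin-4-yl to hydroxy is large (an 11-fold lower number from compound 2 to compound 3 (1.05 log units; beyond the scatter)), and hydroxy in place of methylamino still gives a step beyond the scatter (a 3.1-fold lower number from compound 1 to compound 3 (0.48 log units; beyond the scatter)). The earlier pair showed only that one amide differed from another, whereas compound 3, the carboxylic acid, is now the strongest inhibitor of the three and stands ahead of both amides. Nothing available here explains why hydroxy gives the lowest number. The compounds shown leave open whether a methyl ester or a primary amide on this carbonyl carbon would come as close as the carboxylic acid. They also leave open how an amide bearing a longer chain ending in an amine would compare with methylamino and morpholin-4-yl.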